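A propyl to cyclobutyl change at the assay limit

A few compounds are considered here, and "the series" means these few. Any claim that something is new, unique, unknown or untested is made for them only; others in the source may bear on it.

Values in a functional assay on aorta (Rattus norvegicus) for inhibition (on this read-out higher numbers stand for an effect only at larger amounts of compound and lower numbers for an effect already at smaller amounts), for the measured compounds:
- Compound 1 `CCCNC1=NS(=O)(=O)c2cccc(Cl)c2N1` gives 180000 nM as a number
- Compound 2 `CCNC1=NS(=O)(=O)c2c(Cl)cccc2N1` gives > 300000 nM as a limit
- Compound 3 `CCCNC1=NS(=O)(=O)c2c(Cl)cccc2N1` gives > 300000 nM as a limit

Compound 3 stands at > 300000 nM in this assay and this is only a limit, not a number. The reading here is set by the limit of > 300000 nM in this assay, at which 2 of the 3 values shown sit, and nothing finer.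

In compound 4 `O=S1(=O)N=C(NC2CCC2)Nc2cccc(Cl)c21` cyclobutyl takes the place of propyl on an amine nitrogen. The change in full reads cyclobutyl in place of propyl on an amine nitrogen and the shared core stays untouched.

Among the compounds with values here, the one measured step on a chain is a step that the two limits leave unreadable from compound 2 to compound 3 for a methyl in place of hydrogen on a saturated chain carbon, and it gives no size to carry over. Within the data shown here, compound 1 alone gives a number, yet it offers no measured step for a change on this chain. For compound 3 the limit > 300000 nM remains the only anchor, so in this assay no step beyond the scatter is expected in either direction. The estimated step is a step that the limit leaves unreadable from compound 3 to compound 4 and it is an expectation only. For compound 4 the estimate is 350000 nM with an expected range from 150000 nM to 800000 nM and a report of only a limit is expected to be likely.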

Compound 4, half-maximal effective concentration: > 30000 nM
Compound 4 gave a limit, no number (the forecaster's own chance of this, stated with the estimate: 70%); the middle value is on the limit's open side.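

In this assay compound 4 gives > 30000 nM, which is a limit and not a number. Compound 2 and compound 3 are also reported only as limits, so the steps to compound 4 cannot be read. The compounds shown leave open whether cyclobutyl in place of propyl on an amine nitrogen changes the read-out at all.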